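Cytotoxicity notes: imidazolylmethyl to naphthylmethyl on the amine

The source may hold more compounds than are shown below. What is called first, only, known or untested is meant among the compounds shown, and "the series" means these compounds.

Among the compounds with values here, compound 2 `CCCCOc1ccc(-c2nc3ncccn3c2NCc2nc[nH]c2C)cc1` carries the only number on record in a toxicity assay on A549 cells (Homo sapiens) for cytotoxicity, read by luminescence and CellTiter-Glo, with a stated time of 48 h (a higher number here means that more compound is tolerated, a lower number that less compound is tolerated), where compound 2 gives 100000 nM. Compound 1 `CCCCOc1ccc(-c2nc3ncccn3c2NCc2ccccn2)cc1` sits at the assay limit in this assay, with > 100000 nM. Within the data shown here, the single measured step, a number no higher from compound 1 to compound 2 (the limit leaves the size open), therefore has no readable size, and the limit of > 100000 nM in this assay, at which 1 of the 2 values shown sits, shows that one of the two recorded values is a limit rather than a number.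

Compound 3 `CCCCOc1ccc(-c2nc3ncccn3c2NCc2ccc3ccccc3c2)cc1` is the next member. It differs from compound 2 by naphthalen-2-yl in place of 5-methyl-1H-imidazol-4-yl on a saturated chain carbon bound to a nitrogen on an aromatic ring. Among the measured compounds shown here, the only step that bears on this change is the one from compound 1 to compound 2, which swapped the group on the same saturated chain carbon and whose size could not be read. No shift beyond the scatter in this assay can be inferred from it in either direction.

Compound 3 is accordingly expected to give about 80000 nM in this assay, within 20000 nM to 100000 nM, which corresponds to an estimated step of a 1.3-fold lower number from compound 2 to compound 3 (0.10 log units; within the scatter) from compound 2 to compound 3, with a real chance that the assay again reports only a limit.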

Compound 3, half-maximal cytotoxic concentration: 33000 nM
The estimate for compound 3 lay 2.4-fold (0.38 log units) above the measured number; low and high end bracket the measured number.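

At the saturated chain carbon bound to a nitrogen on an aromatic ring, this assay now yields a step of readable size: naphthalen-2-yl in place of 5-methyl-1H-imidazol-4-yl gives a 3.0-fold lower number from compound 2 to compound 3 (0.48 log units; beyond the scatter), so a change at this position can lower the tolerated concentration beyond the scatter. The same group in place of pyridin-2-yl gives an at least 3.0-fold lower number from compound 1 to compound 3 (0.48 log units; beyond the scatter), which places the lower number with the group of 2 six-membered aromatic rings of carbon only, while both nitrogen-bearing rings stand higher in these three compounds. Compound 1 remains a limit rather than a number, so the second step has only a lower bound on its size, because one value in the series is not a number: the limit of > 100000 nM in this assay, at which 1 of the 3 values shown sits.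

From the compounds shown here alone, whether the lower number goes with the larger ring system or with the absence of ring nitrogen stays open, and a phenyl group on the same carbon would separate these two readings. Going by these compounds, with compound 3 at 33000 nM, how far the number can fall through changes at this position also stays open.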